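Compound 4: methyl in place of methoxy

The source may hold more compounds than are shown below. What is called first, only, known or untested is meant among the compounds shown, and "the series" means these compounds.

In a functional assay on U-87MG ATCC cells (Homo sapiens) for cytotoxicity, read by resazurin assay, with a stated time of 48 h (on this read-out lower numbers stand for stronger inhibition and higher numbers for weaker inhibition), compound 3 `COc1ccc(/C=C2\CS(=O)(=O)C/C(=C\c3ccc([N+](=O)[O-])cc3)C2=O)cc1` gives 2090 nM. Compound 2 `O=C1/C(=C/c2ccc(O)cc2)CS(=O)(=O)C/C1=C\c1ccc([N+](=O)[O-])cc1` gives 2170 nM, within the scatter of compound 3. Compound 1 `Cc1ccc(/C=C2\CS(=O)(=O)C/C(=C\c3ccc(C)cc3)C2=O)cc1` gives 4740 nM, a higher number than compound 3 and beyond the scatter.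

Compound 4 `Cc1ccc(/C=C2\CS(=O)(=O)C/C(=C\c3ccc([N+](=O)[O-])cc3)C2=O)cc1` follows with methyl in place of methoxy on an aromatic carbon, para to a large group (methyl in place of methoxy on an aromatic carbon). Among the measured compounds shown here, one measured step bears on this, though only indirectly: a 1.0-fold lower number from compound 2 to compound 3 (0.02 log units; within the scatter), a change on the oxygen of that group. Compound 1 also carries methyl but differs from compound 4 elsewhere.

The expected result is a 1.1-fold higher number from compound 3 to compound 4 (0.06 log units; within the scatter), with no shift beyond the scatter. For compound 4 the estimated value is 2400 nM, with an expected range of 1300 nM to 4400 nM.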

Compound 4, half-maximal inhibitory concentration: 1390 nM
For compound 4 the middle estimate is 1.7-fold (0.24 log units) above the measured one; the measured number falls inside the stated range.
By their numbers in this assay, from the lowest: compounds 4, 3 and 2 (each within the scatter of the next); then compound 1.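

In this assay, the change from 4-methoxyphenyl to 4-methylphenyl gives a 1.5-fold lower number from compound 3 to compound 4 (0.18 log units; within the scatter) and methyl in place of hydroxy gives a 1.6-fold lower number from compound 2 to compound 4 (0.19 log units; within the scatter), so methyl, methoxy and hydroxy at this position all lie within the scatter of one another with nitro held constant. At the other substituted position, nitro in place of methyl gives a 3.4-fold lower number from compound 1 to compound 4 (0.53 log units; beyond the scatter), a step beyond the scatter. Nothing on hand explains either result.

Open, as far as these compounds go, is how an amine or a carboxylic acid at the methyl position would read. Also open, from the compounds shown here alone, is whether the nitro step recurs with hydroxy or methoxy as the partner group.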